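A 4-chlorophenyl swap on the sulfonyl sulfur

A few compounds are considered here, and "the series" means these few. Any claim that something is new, unique, unknown or untested is made for them only; others in the source may bear on it.

compound 1 (`Cc1ccc(-c2nn(-c3ccccc3)cc2-c2nc3ccccc3n2S(=O)(=O)c2ccccc2)cc1`): 189000 nM
compound 2 (`Cc1ccc(-c2nn(-c3ccccc3)cc2-c2nc3ccccc3n2S(=O)(=O)c2cc(C)ccc2C)cc1`): 231000 nM

Among the compounds with values here, in an ADME assay on cells (Hepatocyte, Mus musculus) for cytotoxicity, read by MTT assay, with a stated time of 24 h (on this read-out lower numbers stand for higher toxicity in this test and higher numbers for lower toxicity in this test), compound 2 stands level with compound 1, the only other measured compound, and the step between them lies within the scatter. Compound 3 (`Cc1ccc(-c2nn(-c3ccccc3)cc2-c2nc3ccccc3n2S(=O)(=O)c2ccc(Cl)cc2)cc1`), not yet measured, carries 4-chlorophenyl in place of 2,5-dimethylphenyl on a sulfonyl sulfur. Within the data shown here, only one measured step bears on this place, 2,5-dimethylphenyl in place of phenyl, and a 1.2-fold higher number from compound 1 to compound 2 (0.09 log units; within the scatter) is that step, so the guide is thin. Among the measured compounds shown here, no measured compound carries 4-chlorophenyl. No change beyond the scatter is therefore expected in this assay, in either direction, and the estimated step, a 1.2-fold lower number from compound 2 to compound 3 (0.06 log units; within the scatter), stays that small. For compound 3 an estimated 200000 nM is expected, within a range of 110000 nM to 350000 nM on repeated measurement.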

Compound 3, half-maximal cytotoxic concentration: 216000 nM
For compound 3 the middle estimate is 1.1-fold (0.03 log units) below the measured one, and the stated range covers the measured number.
By their numbers in this assay, from the lowest: compounds 1, 3 and 2 (each within the scatter of the next).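

In this assay, the swap of groups on the sulfonyl sulfur gives a 1.1-fold lower number from compound 2 to compound 3 (0.03 log units; within the scatter), and chloro in place of hydrogen on an aromatic carbon gives a 1.1-fold higher number from compound 1 to compound 3 (0.06 log units; within the scatter). This adds a halogen-bearing group to the earlier carbon-only comparison, and phenyl, 2,5-dimethylphenyl and 4-chlorophenyl on this sulfonyl sulfur all read level within the scatter in this test. Nothing measured here explains why these three compounds read alike.

On these data alone, all three compounds keep an aromatic ring of carbon only on the sulfonyl sulfur, so it remains open whether an amine or a carboxylic acid on that ring, or a simple alkyl chain in its place, would read differently. As far as these compounds go, the effect of changes elsewhere on the shared core also remains open.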